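The compounds below may be only part of what the source reports. "The series", "measured", "known", "first", "only" and "open" are said of these compounds alone.

Measured in an ADME assay on the whole organism (Mus musculus, strain CD-1) for pharmacokinetics, at a dose of 10 mg/kg by the oral route; a lower number here means that a smaller share of the oral dose reaches the circulation, a higher number that a larger share of the oral dose reaches the circulation:
Compound 1 `CCOc1cc([C@](O)(CCN(C)C)[C@@H](c2cc3cc(Br)ccc3nc2OC)c2cccc(OC)c2F)cc(OC)n1`: 46%
Compound 2 `COc1cc([C@](O)(CCN(C)C)[C@@H](c2cc3cc(Br)ccc3nc2OC)c2cccc(OC)c2F)cc(SC)n1`: 31%
Compound 3 `COc1cc([C@](O)(CCN(C)C)[C@@H](c2cc3cc(C#N)ccc3nc2OC)c2cccc(OC)c2F)cc(SC)n1`: 28%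

Compound 2 sits in the middle of this small set, and only one of its two gaps is clear: the first is a number 15 percentage points lower from compound 1 to compound 2 (beyond the scatter), and the second is a number 3 percentage points lower from compound 2 to compound 3 (within the scatter).

Compound 4 `CCSc1cc([C@](O)(CCN(C)C)[C@@H](c2cc3cc(Br)ccc3nc2OC)c2cccc(OC)c2F)cc(SCC)n1` has not yet been measured. Its structure differs through (a group of 12 heavy atoms (9 carbon, 1 nitrogen, 2 sulfur; one six-membered aromatic ring with 1 hetero atom) in place of a group of 10 heavy atoms (7 carbon, 1 nitrogen, 1 oxygen, 1 sulfur; one six-membered aromatic ring with 1 hetero atom), on a saturated chain carbon bound to an oxygen on a saturated carbon and two saturated chain carbons). Within the data shown here, the swap of ethoxy for methylsulfanyl in compound 2, with its step of a number 15 percentage points lower from compound 1 to compound 2 (beyond the scatter), is the only guide, since it changed the same group. The bromo to cyano step, a number 3 percentage points lower from compound 2 to compound 3 (within the scatter), does not apply, as compound 4 keeps the bromo. A small further fall in this assay is therefore expected, and the estimated step is a number 9 percentage points lower from compound 2 to compound 4 (within the scatter). The expected value for compound 4 is 22%, within an estimated range of 8% to 38%.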

Compound 4, oral bioavailability: 25%
Beside the measured number, compound 4's estimate is 3 percentage points below it; the range from low to high includes it.
By their numbers in this assay, from the lowest: compounds 4, 3 and 2 (each within the scatter of the next); then compound 1.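

In this assay, going from the group of 10 heavy atoms, with one sulfur and one oxygen, to the group of 12 heavy atoms, with two sulfurs, gives a small result (a number 6 percentage points lower from compound 2 to compound 4 (within the scatter)), so a second sulfur adds no clear loss. The clear gap lies between the group of 11 heavy atoms, with two oxygens and no sulfur, and the group with two sulfurs (a number 21 percentage points lower from compound 1 to compound 4 (beyond the scatter)). No measurement here explains these results. Still open, on these data alone, is how an amine or a longer chain on this aromatic ring would behave.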